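A few compounds are considered here, and "the series" means these few. Any claim that something is new, unique, unknown or untested is made for them only; others in the source may bear on it.

In a functional assay on REF cells (Rattus norvegicus) for antiproliferative activity (a lower number here means a stronger inhibitor, a higher number a weaker inhibitor), compound 2 `COc1ccc(/C=C2/C(C)=C(CC(=O)O)c3cc(F)ccc32)cc1` gives 500000 nM, the highest of the two single numbers. Its nearest neighbour is compound 1 `COc1cccc(/C=C2/C(C)=C(CC(=O)O)c3cc(F)ccc32)c1`, which gives 200000 nM; the step of a 2.5-fold higher number from compound 1 to compound 2 (0.40 log units; beyond the scatter) is a modest weakening. Compound 3 `CC1=C(CC(=O)O)c2cc(F)ccc2/C1=C\c1ccc(C)o1` has several entries, 20000 nM; 10000 nM (2 entries), recorded as the several entries of compound 3 in this assay, 20000 nM; 10000 nM (2 entries). Compound 4 `CC1=C(CC(=O)O)c2cc(F)ccc2/C1=C\c1cccs1` arises through the change (thiophen-2-yl in place of 4-methoxyphenyl on a double-bonded chain carbon bound to a double-bonded ring carbon). Among the measured compounds shown here, no measured step exchanges one aromatic ring for another; the only step, a 2.5-fold higher number from compound 1 to compound 2 (0.40 log units; beyond the scatter), concerns a methoxyphenyl group in both forms. Compound 3, however, also bears a five-membered aromatic ring with one hetero atom on that chain carbon, and its numbers lie far below those of compound 2. Compound 4 is therefore expected to give 30000 nM, between 8000 nM and 120000 nM, meaning an estimated step of a 17-fold lower number from compound 2 to compound 4 (1.22 log units; beyond the scatter).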

Compound 4, half-maximal inhibitory concentration: 100000 nM
Estimate against measurement, compound 4: 3.3-fold (0.52 log units) below; the measured number falls inside the stated range.
By their numbers in this assay, from the lowest: compounds 4 and 1 (each within the scatter of the next); then compound 2.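

Replacing 4-methoxyphenyl with thiophen-2-yl at this chain carbon gives a real gain in potency, a 5.0-fold lower number from compound 2 to compound 4 (0.70 log units; beyond the scatter). Set against the 3-methoxyphenyl group, the same ring shows no real difference, a 2.0-fold lower number from compound 1 to compound 4 (0.30 log units; within the scatter). A methoxy group is therefore not needed to hold this level of activity, yet compound 4 does not reach the numbers of compound 3, which has a different five-membered aromatic ring at this carbon: the several entries of compound 3 in this assay, 20000 nM; 10000 nM (2 entries)

This exchange removes the methoxy group and changes the ring at once, and the compounds shown cannot separate those two changes. Going by these compounds, how a plain phenyl or a pyridin-2-yl ring would behave on this carbon remains open.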